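Nitro to chloro on the flat sulfonyl aryl series

The source may report more compounds than this note shows. Statements on the series, on what has been measured and on what is new or still open speak of the compounds shown alone.

Measured in a functional assay on SMMC-7721 cells (Homo sapiens) for cytotoxicity, read by MTT assay, with a stated time of 24 h; on this read-out higher numbers stand for weaker inhibition and lower numbers for stronger inhibition
- compound 1 `O=C1/C(=C/c2cccnc2)CN(S(=O)(=O)c2ccc(Cl)cc2)C/C1=C\c1ccccc1F` gives 16100 nM
- compound 2 `O=C1/C(=C/c2ccncc2)CN(S(=O)(=O)c2ccccc2)C/C1=C\c1ccccc1F` gives 17500 nM
- compound 3 `O=C1/C(=C/c2ccncc2)CN(S(=O)(=O)c2ccc([N+](=O)[O-])cc2)C/C1=C\c1ccccc1F` gives 15800 nM

In this assay the three measured compounds sit close together. Compound 3 lies within the scatter of both compound 1 and compound 2, so no order can be read among them.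

The next compound is compound 4 `O=C1/C(=C/c2ccncc2)CN(S(=O)(=O)c2ccc(Cl)cc2)C/C1=C\c1ccccc1F`, not yet measured. It keeps the rest of compound 3 and exchanges one group, chloro in place of nitro on an aromatic carbon.

Among the measured compounds shown here, no measured step covers this exchange directly. The nearest evidence is at the same place on the ring, where the measured step is a 1.1-fold lower number from compound 2 to compound 3 (0.04 log units; within the scatter), so putting nitro in place of hydrogen there left the number within the scatter. In addition, compound 1 carries a 4-chlorophenyl group too and gives 16100 nM, a value in the same range as the others.

On this evidence, no step beyond the scatter is expected in this assay, and no direction can be given. The estimate amounts to a 1.0-fold higher number from compound 3 to compound 4 (0.01 log units; within the scatter), which is an expected step and not a measured one.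

Compound 4 is expected at 16000 nM, with an estimated range from 10000 nM to 25000 nM.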

Compound 4, half-maximal inhibitory concentration: 9600 nM
Estimate against measurement, compound 4: 1.7-fold (0.22 log units) above; the measured number lies below the stated range.
By their numbers in this assay, from the lowest: compounds 4, 3, 1 and 2 (each within the scatter of the next).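

In this assay the change from 4-nitrophenyl to 4-chlorophenyl gives a 1.6-fold lower number from compound 3 to compound 4 (0.22 log units; within the scatter) and chloro in place of hydrogen on the same aromatic carbon gives a 1.8-fold lower number from compound 2 to compound 4 (0.26 log units; within the scatter) so that, together with a 1.1-fold lower number from compound 2 to compound 3 (0.04 log units; within the scatter) for nitro in place of hydrogen, all three pairs among hydrogen, nitro and chloro at this position stay within the scatter. The new compound also adds a single comparison of the two pyridine isomers, where pyridin-4-yl in place of pyridin-3-yl on the double-bonded chain carbon gives a 1.7-fold lower number from compound 1 to compound 4 (0.22 log units; within the scatter) and again leaves the pair unseparated in this read-out. Nothing measured alongside these numbers bears on what lies behind them.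

The compounds shown leave open whether any group on this aromatic carbon can move the number beyond the scatter, since only hydrogen, nitro and chloro appear there and an amine, a carboxylic acid or a longer chain might behave differently. As far as these compounds go, the pyridine comparison rests on one pair carrying the 4-chlorophenyl group, so whether it holds with nitro or hydrogen in that place also stays open.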